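The source may report more compounds than this note shows. Statements on the series, on what has been measured and on what is new or still open speak of the compounds shown alone.

Three compounds share one core and differ in two places. Compound 1 `CN1CCC(n2cc(S(=O)(=O)c3ccccc3F)c3cccnc32)C1` gives 186 nM in a functional assay on HeLa cells for antagonist activity at 5-hydroxytryptamine receptor 6 (Homo sapiens), read by cAMP accumulation and immunoassay; a higher number here means a weaker inhibitor, a lower number a stronger inhibitor. Compound 2 `CN1CCC(n2cc(S(=O)(=O)c3ccc(Cl)cc3)c3cccnc32)C1` gives 95 nM in the same assay, and compound 3 `O=S(=O)(c1ccc(Cl)cc1)c1cn(C2CCCNC2)c2ncccc12` gives 682 nM. The change from compound 2 to compound 1 is 2-fluorophenyl in place of 4-chlorophenyl on a sulfonyl sulfur, and it made a step of a 2.0-fold higher number from compound 2 to compound 1 (0.29 log units; within the scatter). Compound 2 and compound 3 have the same atoms joined differently: piperidin-3-yl in place of 1-methylpyrrolidin-3-yl on an aromatic nitrogen, a step of a 7.2-fold higher number from compound 2 to compound 3 (0.86 log units; beyond the scatter).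

Compound 4 `O=S(=O)(c1ccccc1F)c1cn(C2CCCNC2)c2ncccc12` has not been measured. It differs from compound 3 by 2-fluorophenyl in place of 4-chlorophenyl on a sulfonyl sulfur, the same change as from compound 2 to compound 1, at a place described in the same words. Among these four compounds this change occurs twice. Because the earlier step from compound 2 to compound 1 was a 2.0-fold higher number from compound 2 to compound 1 (0.29 log units; within the scatter), a change within the usual scatter, a step of similar size is expected from compound 3 to compound 4, that is a 1.9-fold higher number from compound 3 to compound 4 (0.28 log units; within the scatter). The difference between the cores of compound 3 and compound 2, given above, is the only other change in this set, so the estimate rests on one measured pair. Compound 4 is therefore expected to give about 1300 nM, within roughly 500 nM to 3500 nM.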

Compound 4, half-maximal inhibitory concentration: 50 nM
Compound 4: middle estimate off by 26-fold (1.41 log units), on the high side; measured number below the stated range.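

On the core of compound 3, putting 2-fluorophenyl in place of 4-chlorophenyl gave a 14-fold lower number from compound 3 to compound 4 (1.13 log units; beyond the scatter), so the step seen on the core of compound 2 did not carry over: the same change on two cores in this assay, a 2.0-fold higher number (0.29 log units; within the scatter) from compound 2 to compound 1 and a 14-fold lower number (1.13 log units; beyond the scatter) from compound 3 to compound 4, 27-fold (1.43 log units) apart, beyond the scatter of two such steps The same four compounds can be read the other way, with piperidin-3-yl in place of 1-methylpyrrolidin-3-yl giving a 3.7-fold lower number from compound 1 to compound 4 (0.57 log units; beyond the scatter), and this change also depends on what else is present: the same change on two cores in this assay, a 7.2-fold higher number (0.86 log units; beyond the scatter) from compound 2 to compound 3 and a 3.7-fold lower number (0.57 log units; beyond the scatter) from compound 1 to compound 4, 27-fold (1.43 log units) apart, beyond the scatter of two such steps This shows that in this assay the two changes do not act independently in these compounds, so a step measured on one core was a poor guide to the other, but it does not show why, and one pair on each core gives no general rule for the series.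

The compounds shown leave open whether the reversal comes from the ring size or the methyl group, which change together here; pyrrolidin-3-yl on the aromatic nitrogen would separate them. They also leave open how a plain phenyl on the sulfonyl sulfur would behave on either core.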